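Oxygen insertion into the sulfamoylethyl side chain

The source may report more compounds than this note shows. Statements on the series, on what has been measured and on what is new or still open speak of the compounds shown alone.

Within the data shown here, compound 2 `NS(=O)(=O)CCNc1nonc1/C(=N/O)Nc1ccc(F)c(Br)c1` gives 11 nM in an assay on HeLa cells for inhibition of Indoleamine 2,3-dioxygenase 1 (Homo sapiens), read by spectrophotometry, with a stated time of 24 h (a higher number here means that more compound is needed for the effect, a lower number that less compound is needed), the lowest of the two numbers so far, while compound 1 `[O-][S+]1CC(Nc2nonc2/C(=N/O)Nc2ccc(F)c(Br)c2)C1` gives 79 nM in this assay. Among the measured compounds shown here, the only measured step, a 7.2-fold lower number from compound 1 to compound 2 (0.86 log units; beyond the scatter), swapped the whole side chain and does not speak to the change at hand. Compound 3 `NS(=O)(=O)CCONc1nonc1/C(=N/O)Nc1ccc(F)c(Br)c1` differs from compound 2 by 2-sulfamoylethoxy in place of 2-sulfamoylethyl on a nitrogen on an aromatic ring. For the measured compounds named here, no measured pair separates 2-sulfamoylethyl from 2-sulfamoylethoxy on this nitrogen, so the estimate rests on compound 2 alone. The step of a 1.6-fold higher number from compound 2 to compound 3 (0.21 log units; within the scatter) is expected to stay within the scatter. Compound 3 is estimated at 18 nM, range 6 nM to 70 nM.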

Compound 3, half-maximal effective concentration: 27 nM
Estimate against measurement, compound 3: 1.5-fold (0.18 log units) below, and the stated range covers the measured number.
By their numbers in this assay, from the lowest: compound 2; then compound 3; then compound 1.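

Oxygen insertion on this nitrogen is not neutral: 2-sulfamoylethoxy in place of 2-sulfamoylethyl gives a 2.5-fold higher number from compound 2 to compound 3 (0.39 log units; beyond the scatter), a modest step but beyond the scatter. The open 2-sulfamoylethoxy chain still compares well with the four-membered ring group of compound 1, with a 2.9-fold lower number from compound 1 to compound 3 (0.47 log units; beyond the scatter). No available evidence bears on the origin of either step.

From the compounds shown here alone, whether a longer chain behaves like these two remains open. So does the effect of an amine or a carboxylic acid in place of the terminal sulfamoyl group.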